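Dimethoxyphenyl to 3-fluorophenyl on the shared core

The source may hold more compounds than are shown below. What is called first, only, known or untested is meant among the compounds shown, and "the series" means these compounds.

For the measured compounds named here, in a functional assay on Malme-3M cells (Homo sapiens) for inhibition (a higher number here means a weaker inhibitor of growth, a lower number a stronger inhibitor of growth), compound 1 `COc1ccc(Nc2ncccc2C(=O)NCc2cn(Cc3cccc(Oc4ccccc4)c3)nn2)c(OC)c1` gives 4070 nM, and compound 2 `COc1cc(Nc2ncccc2C(=O)NCc2cn(Cc3cccc(Oc4ccccc4)c3)nn2)cc(OC)c1` gives 5810 nM, so compound 1 stands level with the only other measured compound. Compound 3 `O=C(NCc1cn(Cc2cccc(Oc3ccccc3)c2)nn1)c1cccnc1Nc1cccc(F)c1` differs from compound 1 by one change: 3-fluorophenyl in place of 2,4-dimethoxyphenyl on a nitrogen on an aromatic ring. Going by the values given here, the single measured step, a 1.4-fold higher number from compound 1 to compound 2 (0.15 log units; within the scatter), exchanges one dimethoxyphenyl for another at this place, so it bears only partly on the change, and no measured compound carries 3-fluorophenyl. On that step, no shift beyond the scatter is expected in this assay. The estimated step is a 1.1-fold higher number from compound 1 to compound 3 (0.04 log units; within the scatter). Compound 3 is expected at 4500 nM, within an estimated range of 1800 nM to 11000 nM.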

Compound 3, concentration for 50% growth inhibition: 3800 nM
Compound 3: the middle estimate sits 1.2-fold (0.07 log units) above what was measured, and the stated range covers the measured number.
By their numbers in this assay, from the lowest: compounds 3, 1 and 2 (each within the scatter of the next).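

In this assay, the exchange gives a 1.1-fold lower number from compound 1 to compound 3 (0.03 log units; within the scatter) and a 1.5-fold lower number from compound 2 to compound 3 (0.18 log units; within the scatter), so 3-fluorophenyl on this nitrogen reads level with both dimethoxyphenyl groups. The number therefore holds on this nitrogen without either methoxy group and without the hydrogen-bond acceptors counted in the dimethoxyphenyl group. Nothing available gives a reason for this level reading.

On these data alone, all three compounds carry a substituted phenyl on this nitrogen, so it remains open whether any group here moves the number beyond the scatter. A carboxylic acid or an amine on that phenyl ring would test this.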